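The source may report more compounds than this note shows. Statements on the series, on what has been measured and on what is new or still open speak of the compounds shown alone.

The series is followed in a functional assay on HepG2 cells (Homo sapiens) for antiproliferative activity, read by MTT assay, with a stated time of 72 h (on this read-out lower numbers stand for stronger inhibition and higher numbers for weaker inhibition), where two compounds have been measured so far. Compound 1, `CCCCCc1ccc(-c2cn(C/C=C3\OC(=O)C(OCc4ccccc4)=C3OCc3ccccc3)nn2)cc1`, reaches only a limit of the assay; in this assay compound 1 gives > 100000 nM, which is a limit and not a number. For the measured compounds named here, compound 2, `O=C1O[C@H]([C@@H](O)Cn2cc(CNS(=O)(=O)c3ccc(F)cc3)nn2)C(OCc2ccccc2)=C1OCc1ccccc1`, is the one measured compound with a numerical value: in this assay compound 2 gives 18300 nM. Compound 2 therefore stands as the only number shown. The remaining value, that of compound 1, is a limit, as the limit of > 100000 nM in this assay, at which 1 of the 2 values shown sits, shows.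

Compound 3, `O=C1O[C@H]([C@@H](O)Cn2ccnn2)C(OCc2ccccc2)=C1OCc1ccccc1`, is not yet measured. It differs from compound 2 in one place: hydrogen in place of (((4-fluorophenyl)sulfonyl)amino)methyl on an aromatic carbon. The shared core of compound 2, with its two benzyloxy groups and the hydroxyl-bearing chain, is kept; only the substituent on the five-membered aromatic ring with 3 nitrogen is removed.

Going by the values given here, with no measured pair of compounds differing in one place, the size of this step can only be estimated. Compound 3 is expected to be somewhat weaker than compound 2, a step of a 2.2-fold higher number from compound 2 to compound 3 (0.34 log units; beyond the scatter) in this assay. Compound 3 is therefore estimated at 40000 nM in this assay, within a range from 12000 nM to 150000 nM.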

Compound 3, half-maximal inhibitory concentration: > 100000 nM
Compound 3: no number, only a limit; the forecaster's own chance of this, stated with the estimate: 35%; middle value at least 2.5-fold (0.39 log units) away from the limit.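

With the (((4-fluorophenyl)sulfonyl)amino)methyl group replaced by hydrogen on the aromatic carbon of the five-membered aromatic ring with 3 nitrogen, this assay gives the series its first readable step, an at least 5.4-fold higher number from compound 2 to compound 3 (0.73 log units; beyond the scatter). On the core shared by these two compounds, the measurable antiproliferative activity of compound 2 therefore does not survive the loss of this substituent, so this position is one where the choice of group changes the read-out and bare hydrogen is not enough. The size of the step is only a lower bound, since the reading for compound 3 is a limit and not a number, and such limits now make up most of what is shown: the limit of > 100000 nM in this assay, at which 2 of the 3 values shown sit.

Which part of the departed group matters remains open, as the compounds shown do not tell whether a plain aminomethyl group, a carboxylic acid or a simple phenyl ring on the same aromatic carbon would keep any of the activity of compound 2. They also leave open whether a sulfonamide without the fluorine on its six-membered aromatic ring would read the same as compound 2.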